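The compounds below may be only part of what the source reports. "The series", "measured", "known", "first", "only" and "open" are said of these compounds alone.

Cytotoxicity numbers in an ADME assay on RAW264.7 cells (Mus musculus) for cytotoxicity, read by MTT assay, with a stated time of 72 h, tested at 100 uM (on this read-out lower numbers stand for a weaker effect and higher numbers for a stronger effect at the one concentration tested), for the three measured compounds:

compound 1 `O=C(Cn1c(=O)oc2ccccc21)NCc1ccccn1`: 38.7%
compound 2 `O=C(Cn1c(=O)oc2cc([N+](=O)[O-])ccc21)Nc1ccccc1`: 26.4%
compound 3 `O=C(Cn1c(=O)oc2cc([N+](=O)[O-])ccc21)NCc1ccco1`: 60.1%

Compound 3 gives the highest number of the three in this assay. Compound 1 gives a lower number, and compound 2 gives the lowest, both separated from compound 3 by more than the scatter. Going by the values given here, the one single-point step measured is a number 33.7 percentage points higher from compound 2 to compound 3 (beyond the scatter), a large rise.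

The next compound, compound 4 `O=C(Cn1c(=O)oc2cc([N+](=O)[O-])ccc21)NCc1ccccn1`, is reached from compound 3 by pyridin-2-yl in place of furan-2-yl on a saturated chain carbon bound to an amide-type nitrogen.

Among the compounds with values here, no measured step exchanges furan-2-yl for pyridin-2-yl, so the size of this step is not directly known. The step from compound 2 to compound 3 concerns a different change, phenyl to (furan-2-yl)methyl, and says only that the (furan-2-yl)methyl compound gives the highest number. Compound 1 carries the same (pyridin-2-yl)methyl on the amide-type nitrogen as compound 4 but differs elsewhere, and compound 1 gives 38.7%, a lower number than compound 3. A moderate fall beyond the scatter is therefore expected, a number 13.1 percentage points lower from compound 3 to compound 4 (beyond the scatter), with wide uncertainty. Compound 4 is estimated at 47%, expected between 30% and 64%.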

Compound 4, a percentage reported as inhibition, at one concentration (the size of the read-out at that concentration, not a potency): 33.4%
Compound 4: the middle estimate sits 13.6 percentage points above what was measured, and the stated range covers the measured number.
By their numbers in this assay, from the lowest: compounds 2, 4 and 1 (each within the scatter of the next, the first and the last beyond it); then compound 3.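

In this assay, going by these compounds alone, the ring on the saturated chain carbon bound to an amide-type nitrogen matters with the nitro-bearing core: the exchange of furan-2-yl for pyridin-2-yl gives a number 26.7 percentage points lower from compound 3 to compound 4 (beyond the scatter), the first measured change at this position. The rise seen for (furan-2-yl)methyl in place of phenyl has no counterpart with (pyridin-2-yl)methyl, where the reading is a number 7 percentage points higher from compound 2 to compound 4 (within the scatter), so among these compounds that rise belongs to the furan-2-yl compound and not to every ring-bearing methyl group on the amide-type nitrogen. Within the data shown here, the first reading of the nitro group, taken with (pyridin-2-yl)methyl in place, is a number 5.3 percentage points lower from compound 1 to compound 4 (within the scatter), so nitro in place of hydrogen does not separate this pair.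

Open, on these data alone, is whether nitro in place of hydrogen reads the same with furan-2-yl on the chain, and whether a longer chain carrying furan-2-yl, or an amine in place of the nitro, keeps the number of compound 3 at 60.1%. Nothing shown here offers an explanation for these numbers.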